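Trimming One Methoxy Group From a Pyrazolyl Chalcone

A few compounds are considered here, and "the series" means these few. Any claim that something is new, unique, unknown or untested is made for them only; others in the source may bear on it.

Of the compounds shown here, three built on a shared core have been tested in a functional assay on KM12 cells (Homo sapiens) for cytotoxicity, read by sulforhodamine B assay, with a stated time of 48 h, tested at 10 uM; a lower number here means a stronger effect, a higher number a weaker effect of the compound at the concentration tested. Compound 1 `COc1ccc(-c2cc(/C=C/C(=O)c3ccc(N)cc3)[nH]n2)cc1` gives -67%; compound 2 `COc1ccc(-c2cc(/C=C/C(=O)c3ccc(N)cc3)[nH]n2)cc1OC` gives -79%; compound 3 `COc1cc(C(=O)/C=C/c2cc(-c3cc(OC)c(OC)c(OC)c3)n[nH]2)cc(OC)c1OC` gives -90%. The change from compound 2 to compound 1 is hydrogen in place of methoxy on an aromatic carbon, and it produced a number 12 percentage points higher from compound 2 to compound 1 (beyond the scatter). How the core of compound 3 differs from that of compound 2 is not broken down here. Compound 4 `COc1ccc(-c2cc(/C=C/C(=O)c3cc(OC)c(OC)c(OC)c3)[nH]n2)cc1OC` is not yet measured. It differs from compound 3 by hydrogen in place of methoxy on an aromatic carbon, the same kind of change as before, although here the carbon is also meta to a methoxy group. Because the earlier step gave a number 12 percentage points higher from compound 2 to compound 1 (beyond the scatter), a similar weakening is expected for compound 4. The expected step for compound 4 is a number 12 percentage points higher from compound 3 to compound 4 (beyond the scatter), giving an estimated -78%, plausibly between -92% and -62%.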

Compound 4, a percentage reported as activity, at one concentration (the size of the read-out at that concentration, not a potency): -81%
Beside the measured number, compound 4's estimate is 3 percentage points above it; low and high end bracket the measured number.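

In this assay, putting hydrogen in place of methoxy on an aromatic carbon gave a number 9 percentage points higher from compound 3 to compound 4 (within the scatter), so this step alone cannot be told apart from repeat-measurement noise. Set beside the earlier step, the change looks about the same size on both cores: the same change on two cores in this assay, a number 12 percentage points higher (beyond the scatter) from compound 2 to compound 1 and a number 9 percentage points higher (within the scatter) from compound 3 to compound 4, 3 percentage points apart, within the scatter of two such steps. That supports carrying this step between these two cores at this one concentration, but it does not show that the change would behave the same way on any other core, or that it would in other assays.

The compounds shown carry only methoxy or hydrogen at the changed place. As far as these compounds go, what a hydroxyl group or a longer chain such as ethoxy would do there remains open.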